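This account rests on a few compounds, and the source may have more. Where it says the series, first, only, none or still open, it means among the compounds named here.

Working notes on the series. Within the data shown here, compound 1 `COc1ccc(-c2cc(/C=C/C(=O)c3ccc(N)cc3)[nH]n2)cc1` is the first member; in a functional assay on HCT-15 cells (Homo sapiens) for inhibition, read by sulforhodamine B assay, with a stated time of 48 h (a higher number here means a weaker inhibitor of growth, a lower number a stronger inhibitor of growth), compound 1 gives 3620 nM. Compound 2 `COc1ccc(-c2cc(/C=C/C(=O)c3ccc(N)cc3)[nH]n2)cc1OC` carries one further methoxy group, and in this assay compound 2 gives 5370 nM. The change between them is hydrogen in place of methoxy on an aromatic carbon and the step it made is a 1.5-fold lower number from compound 2 to compound 1 (0.17 log units; within the scatter). Compound 3 `COc1cc(C(=O)/C=C/c2cc(-c3cc(OC)c(OC)c(OC)c3)n[nH]2)cc(OC)c1OC` has a different core; how the core of compound 3 differs from that of compound 2 is not broken down here. In this assay compound 3 gives 3290 nM, and its numbers against compound 1 and compound 2 lie within the scatter, so no order is drawn among the three.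

Compound 4 `COc1ccc(-c2cc(/C=C/C(=O)c3cc(OC)c(OC)c(OC)c3)[nH]n2)cc1OC` is not yet measured. Its difference from compound 3 is hydrogen in place of methoxy on an aromatic carbon. This is the same kind of change as that from compound 2 to compound 1, not the same: around the place in compound 3 the carbon is also meta to a methoxy group (2 heavy atoms), which the place in compound 2 lacks. The step expected from compound 3 to compound 4 is a 1.2-fold lower number from compound 3 to compound 4 (0.07 log units; within the scatter), placed beside a 1.5-fold lower number from compound 2 to compound 1 (0.17 log units; within the scatter); this rests on the step from compound 2 to compound 1 being within the scatter, so a comparably small step is expected here. For compound 4 the estimated value in this assay is 2800 nM, with a range from 1200 nM to 6500 nM.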

Compound 4, concentration for total growth inhibition: 3850 nM
Estimate against measurement, compound 4: 1.4-fold (0.14 log units) below, within the range that was stated.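

In this assay, hydrogen in place of methoxy on an aromatic carbon gives a 1.2-fold higher number from compound 3 to compound 4 (0.07 log units; within the scatter), so on this core too the change leaves the number within the scatter. Set beside the earlier step, the two cores cannot be told apart for this change: the same change on two cores in this assay, a 1.5-fold lower number (0.17 log units; within the scatter) from compound 2 to compound 1 and a 1.2-fold higher number (0.07 log units; within the scatter) from compound 3 to compound 4, 1.7-fold (0.24 log units) apart, within the scatter of two such steps. The change therefore carries from one core to the other without a step that can be read, although the opposite signs of the two steps mean nothing at this size, and these two pairs do not show that the methoxy group is without influence across the series or that the two cores would respond alike to a different change.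

Still open, as far as these compounds go, is whether another group at this place, such as a hydroxyl, a fluorine or a longer chain like ethoxy, would give a step beyond the scatter on either core. Also open is whether the same small steps would hold in cell lines other than the one shown here.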